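Methyl for Methoxy on the Aromatic Ring of Compound 2

The source may hold more compounds than are shown below. What is called first, only, known or untested is meant among the compounds shown, and "the series" means these compounds.

Of the compounds shown here, three sharing one core have been measured in a functional assay on the whole organism (strain CF-1) with Mus musculus as the target, in the writhing test, with a stated time of 15 min; on this read-out lower numbers stand for an effect already at smaller amounts and higher numbers for an effect only at larger amounts of compound. Compound 1 `CNC1=NC2(CCCCO2)CCS1` gives 52 mg/kg. Compound 2 `COc1ccc(C(=O)/N=C2\NC3(CCCCO3)CCS2)cc1` gives 62 mg/kg in this assay, and compound 3 `COc1ccc(C(=O)/N=C2\NC3(CCCCO3)CCS2)cc1OC` gives 200 mg/kg. Within the data shown here, compound 2 thus stands second highest of the three numbers: compound 1 lies within the scatter of it, while compound 3 lies beyond it, the only step measured here being a 3.2-fold higher number from compound 2 to compound 3 (0.51 log units; beyond the scatter).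

Compound 4 `Cc1ccc(C(=O)/N=C2\NC3(CCCCO3)CCS2)cc1` differs from compound 2 by methyl in place of methoxy on an aromatic carbon. Among the measured compounds shown here, the one measured step bears on it only loosely, since it added a second methoxy rather than exchanging one. An exchange of one small group for another of this kind gives no ground for a large shift, so compound 4 is expected to stand close to compound 2, with a step of a 1.1-fold higher number from compound 2 to compound 4 (0.05 log units; within the scatter) in this assay, not clearly beyond the scatter. Compound 4 is accordingly estimated at 70 mg/kg in this assay, within a range from 35 mg/kg to 140 mg/kg.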

Compound 4, dose for half-maximal effect: 60 mg/kg
Estimate against measurement, compound 4: 1.2-fold (0.07 log units) above, within the range that was stated.
By their numbers in this assay, from the lowest: compounds 1, 4 and 2 (each within the scatter of the next); then compound 3.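

In this assay, the exchange of methoxy for methyl on this aromatic carbon, para to a large group, gives a 1.0-fold lower number from compound 2 to compound 4 (0.01 log units; within the scatter), so this read-out does not separate the two groups at this place. Among these compounds, the only earlier step, a 3.2-fold higher number from compound 2 to compound 3 (0.51 log units; beyond the scatter), added a second methoxy and so could not show what happens when the first methoxy is exchanged; the new step shows that the oxygen of that group can go without a change beyond the scatter. Nothing at hand accounts for the two groups reading alike. Going by these compounds, whether this holds for groups of another kind remains open, for instance an amine or a carboxylic acid at the same carbon. A longer chain such as butoxy, or plain hydrogen there, is equally untested by the compounds shown.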